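The compounds below may be only part of what the source reports. "The series", "measured", "known", "first", "only" and "open" are said of these compounds alone.

Going by the values given here, in an ADME assay on NIH3T3 cells (Mus musculus) for cytotoxicity (on this read-out lower numbers stand for higher toxicity in this test and higher numbers for lower toxicity in this test), compound 3 (`Fc1cccc(COc2ccc(Nc3ncnc4cc(C#CCN5CCCC5)sc34)cc2Cl)c1`) gives 6.4 uM, the only actual number so far. Compound 1 (`CC(C)(C)CC#Cc1cc2ncnc(Nc3ccc(OCc4cccc(F)c4)c(Cl)c3)c2s1`) reads > 50 uM, which is a limit of the assay. Compound 2 (`Fc1cccc(COc2ccc(Nc3ncnc4cc(C#CCN5CCNCC5)sc34)cc2Cl)c1`) reads > 50 uM, which is also a limit. The remaining evidence is thus (the limit of > 50 uM in this assay, at which 2 of the 3 values shown sit).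

The next compound is compound 4 (`CC(C)(C)OC(=O)N1CCC[C@H]1C#Cc1cc2ncnc(Nc3ccc(OCc4cccc(F)c4)c(Cl)c3)c2s1`), and the change leading to it is 1-(tert-butoxycarbonyl)pyrrolidin-2-yl in place of (pyrrolidin-1-yl)methyl on a triple-bonded carbon. In words, this is 1-(tert-butoxycarbonyl)pyrrolidin-2-yl in place of (pyrrolidin-1-yl)methyl on a triple-bonded carbon.

Among the compounds with values here, two measured steps bear on this change, as both involve the group that compound 4 gives up. One is an at least 7.8-fold lower number from compound 1 to compound 3 (0.89 log units; beyond the scatter), and the other is an at least 7.8-fold lower number from compound 2 to compound 3 (0.89 log units; beyond the scatter). Among these three compounds, only compound 3 carries the (pyrrolidin-1-yl)methyl group, and only compound 3 falls short of the limit. Within the data shown here, no measured step covers the entering group, and the two limits leave the true size of both steps open, so the expectation is loose. Losing that group should reverse the direction of those steps, giving a higher number of at least modest size. The expected step in this assay is a 4.7-fold higher number from compound 3 to compound 4 (0.67 log units; beyond the scatter). The estimate for compound 4 is 30 uM, with an expected range of 9 uM to 90 uM.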

Compound 4, half-maximal toxic concentration: > 100 uM
Compound 4: a limit, no number (the forecaster's own chance of this, stated with the estimate: 50%); middle value at least 3.3-fold (0.52 log units) away from the limit.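

In this assay compound 4 gives > 100 uM, which is a limit of the assay and not a number. Even so, the change on the triple-bonded carbon can be read as an at least 15-fold higher number from compound 3 to compound 4 (1.19 log units; beyond the scatter), which shows that a five-membered non-aromatic ring with 1 hetero atom at this place does not by itself go with the low number of compound 3, since compound 3 and compound 4 both carry one. The steps to compound 4 from compound 1 and from compound 2 cannot be read, as each of them joins two limits: the limit of > 100 uM in this assay, at which 1 of the 4 values shown sits.

This single change swaps (pyrrolidin-1-yl)methyl for 1-(tert-butoxycarbonyl)pyrrolidin-2-yl, so it alters both how the ring is attached and what sits on its nitrogen, and the compounds shown cannot separate the two. On these data alone, a pyrrolidin-2-yl group with a free secondary amine in place of the tert-butoxycarbonyl, or the opposite configuration at the defined stereocentre, would bear on this, and the true value of compound 4 stays open as well.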